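This account rests on a few compounds, and the source may have more. Where it says the series, first, only, none or still open, it means among the compounds named here.

Measured so far in a functional assay on A549 cells (Homo sapiens) for inhibition, read by colorimetric assay and MTT assay, with a stated time of 72 h; a higher number here means a weaker inhibitor, a lower number a stronger inhibitor
- compound 1 `C/C1=C\CC[C@@]2(C)O[C@@H]2[C@H]2OC(=O)[C@@H](CN3CCCC3)[C@@H]2C[C@H]1O` gives 10000 nM
- compound 2 `C/C1=C\CC[C@@]2(C)O[C@@H]2[C@H]2OC(=O)[C@@H](CN3CCCCC3)[C@@H]2C[C@H]1O` gives 18000 nM
- compound 3 `C/C1=C\CC[C@@]2(C)O[C@@H]2[C@H]2OC(=O)[C@@H](CN3CCCC3)[C@@H]2C[C@@H]1O` gives 9000 nM

Compound 3, at 9000 nM, lies within the usual scatter of both compound 1 and compound 2, so no order among the three is claimed. The next step leads to compound 4 `C/C1=C\CC[C@@]2(C)O[C@@H]2[C@H]2OC(=O)[C@@H](CN3CCCCC3)[C@@H]2C[C@@H]1O`, with piperidin-1-yl in place of pyrrolidin-1-yl on a saturated chain carbon bound to a saturated ring carbon.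

The same swap has been measured once, in the other configuration: a 1.8-fold higher number from compound 1 to compound 2 (0.26 log units; within the scatter). The remaining measured step, a 1.1-fold lower number from compound 1 to compound 3 (0.05 log units; within the scatter), goes with the fact that compounds 1 and 3 differ only in the configuration as drawn and shows no separation beyond the scatter. A small rise of similar size is therefore expected in this assay, not clearly beyond the scatter. The expected step is a 1.8-fold higher number from compound 3 to compound 4 (0.25 log units; within the scatter). For compound 4 the estimated value is 16000 nM, with an expected range from 9000 nM to 30000 nM.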

Compound 4, half-maximal inhibitory concentration: 6000 nM
For compound 4 the middle estimate is 2.7-fold (0.43 log units) above the measured one; the measured number lies below the stated range.
By their numbers in this assay, from the lowest: compounds 4, 3, 1 and 2 (each within the scatter of the next, the first and the last beyond it).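

Among the compounds shown here, the swap of pyrrolidin-1-yl for piperidin-1-yl on a saturated chain carbon bound to a saturated ring carbon now reads a 1.5-fold lower number from compound 3 to compound 4 (0.18 log units; within the scatter) in this assay, so the step stays within the scatter in both configurations, yet it does not carry over as one constant step: the same change on two cores in this assay, a 1.8-fold higher number (0.26 log units; within the scatter) from compound 1 to compound 2 and a 1.5-fold lower number (0.18 log units; within the scatter) from compound 3 to compound 4, 2.7-fold (0.43 log units) apart, beyond the scatter of two such steps The configuration at the stereocentre now gives a first step beyond the scatter, though a modest one, a 3.0-fold lower number from compound 2 to compound 4 (0.48 log units; beyond the scatter), and this separation appears with piperidin-1-yl: the fact that compounds 2 and 4 differ only in the configuration as drawn With pyrrolidin-1-yl, compound 1 and compound 3 go against any general effect of configuration, showing a 1.1-fold lower number from compound 1 to compound 3 (0.05 log units; within the scatter).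

On these data alone, whether this dependence on configuration extends to other amines, such as morpholin-4-yl or dimethylamino, remains open. Also open, as far as these compounds go, is how a carboxylic acid or a longer chain at this place would read in this assay.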